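Notes on the amine side chain: compound 2 to compound 3

The source may report more compounds than this note shows. Statements on the series, on what has been measured and on what is new or still open speak of the compounds shown alone.

Measured so far:
Compound 1 `N[C@@H](CC1CCCCC1)CN(C(=O)[C@@H]1C[C@H]1c1ccccc1)c1ccc(-c2ccccc2)cc1`: 1.7 nM in a functional assay for agonist activity at G protein-coupled receptor 88 (Homo sapiens), read by HTRF and cAMP accumulation; on this read-out lower numbers stand for an effect already at smaller amounts and higher numbers for an effect only at larger amounts of compound
Compound 2 `CC(C)(N)CN(C(=O)[C@@H]1C[C@H]1c1ccccc1)c1ccc(-c2ccccc2)cc1`: 1.4 nM in this assay

In this assay compound 2 gives 1.4 nM and compound 1 gives 1.7 nM; the two lie within the scatter of each other, so neither stands apart. Within the data shown here, the one step measured so far, a 1.2-fold lower number from compound 1 to compound 2 (0.08 log units; within the scatter), exchanges 1-amino-2-cyclohexylethyl for 1-amino-1-methylethyl on a saturated chain carbon bound to an amide-type nitrogen and shows nothing beyond the scatter.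

Compound 3 `O=C([C@@H]1C[C@H]1c1ccccc1)N(CCNCC1CCCCC1)c1ccc(-c2ccccc2)cc1` is not yet measured. Its change from compound 2 is ((cyclohexylmethyl)amino)methyl in place of 1-amino-1-methylethyl on a saturated chain carbon bound to an amide-type nitrogen. Among the measured compounds shown here, the step from compound 1 to compound 2 bears on it only in part: it shows that carrying or dropping a cyclohexyl on that chain carbon left the number unchanged, whereas in compound 3 the cyclohexylmethyl is attached to the amine nitrogen, and no measured step covers that. A small step in this assay is therefore expected, if any, toward a higher number, estimated as a 2.9-fold higher number from compound 2 to compound 3 (0.46 log units; beyond the scatter). For compound 3 the expected value in this assay is 4 nM, within 1 nM to 20 nM.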

Compound 3, half-maximal effective concentration: 6.6 nM
Beside the measured number, compound 3's estimate is 1.7-fold (0.22 log units) below it, within the range that was stated.
By their numbers in this assay, from the lowest: compounds 2 and 1 (each within the scatter of the next); then compound 3.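

In this assay this position now shows its first change beyond the scatter, though a modest one: a 4.7-fold higher number from compound 2 to compound 3 (0.67 log units; beyond the scatter), and a 3.9-fold higher number from compound 1 to compound 3 (0.59 log units; beyond the scatter). A cyclohexyl on the chain, as in compound 1, stays within the scatter of compound 2, whereas compound 3, with cyclohexylmethyl on the amine nitrogen, gives a higher number than either, so in this set the cyclohexyl-bearing groups differ in their effect according to where the ring is attached. No supporting evidence bears on this result.

The step to compound 3 both removes the chain branching and places a substituent on the amine nitrogen, and the compounds shown do not separate these two changes. A plain 2-aminoethyl and a 2-(methylamino)ethyl group would show how much of the step belongs to each, and whether the size of the nitrogen substituent matters.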